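Fluoro to hydroxy in a cytotoxicity comparison

This account rests on a few compounds, and the source may have more. Where it says the series, first, only, none or still open, it means among the compounds named here.

Compound 1 (`O=C(Nc1ccc(F)c(-c2nc3ccccc3o2)c1)c1cc([N+](=O)[O-])ccc1Cl`) and compound 2 (`O=C(Nc1ccc(F)c(-c2nc3ccccc3s2)c1)c1cc([N+](=O)[O-])ccc1Cl`) have both been tested in an ADME assay on Raji cells (Homo sapiens) for cytotoxicity, with a stated time of 72 h (on this read-out lower numbers stand for an effect already at smaller amounts and higher numbers for an effect only at larger amounts of compound), so far. Compound 1 gives > 25000 nM as a limit of the assay. Compound 2 gives > 25000 nM as a limit too, not as a number. The picture so far is the limit of > 25000 nM in this assay, at which 2 of the 2 values shown sit, and nothing more, so compound 2 offers no exact starting value.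

Compound 3 (`O=C(Nc1ccc(O)c(-c2nc3ccccc3s2)c1)c1cc([N+](=O)[O-])ccc1Cl`) differs from compound 2 by hydroxy in place of fluoro on an aromatic carbon with hydroxy in place of fluoro on an aromatic carbon, ortho to a 1,3-benzothiazol-2-yl group and para to a large group. Among the measured compounds shown here, only one measured step is available: a step that the two limits leave unreadable from compound 1 to compound 2 concerns a different place in the structure and gives no size to carry over. For the measured compounds named here, no step of definite size or direction can therefore be expected in this assay from these data. The estimated change is a number no higher from compound 2 to compound 3 (the limit leaves the size open) and nothing larger is expected. Compound 3 is estimated at 25000 nM with an expected range from 8000 nM to 50000 nM and a good chance of another limit instead of a number.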

Compound 3, half-maximal effective concentration: > 25000 nM
Compound 3: a limit, no number; the forecaster's own chance of this, stated with the estimate: 70%; the middle value sits exactly at the limit.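

In this assay compound 3 gives > 25000 nM, which is a limit and not a number. Compound 2 also stands at a limit, so the exchange of fluoro for hydroxy cannot be read as a step between compound 2 and compound 3. The compounds shown leave open whether they differ at all, since all stand at one limit: the limit of > 25000 nM in this assay, at which 3 of the 3 values shown sit.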